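Ethynyl to iodo swap in a nucleoside series

This account rests on a few compounds, and the source may have more. Where it says the series, first, only, none or still open, it means among the compounds named here.

Measured compounds and values:
Compound 1 `C#Cc1cn([C@@H]2O[C@H](CO)[C@@H](O)[C@H]2O)c2ncnc(NC)c12` gives > 20000 nM in a functional assay on HCT-116 cells (Homo sapiens), read by MTT assay, with a stated time of 72 h; on this read-out lower numbers stand for stronger inhibition and higher numbers for weaker inhibition; this is a limit of the assay, not a number.
Compound 2 `C#Cc1cn([C@@H]2O[C@H](CO)[C@@H](O)[C@H]2O)c2nc(C)nc(N)c12` gives > 20000 nM in this assay; this too is a limit of the assay.
Compound 3 `Cc1nc(N)c2c(I)cn([C@@H]3O[C@H](CO)[C@@H](O)[C@H]3O)c2n1` gives > 20000 nM in this assay; again only a limit is reported.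

Compound 1 and compound 2 are built from the same atoms joined differently; the difference between the two cores is not broken down here. Compound 3 arises from compound 2 by iodo in place of ethynyl on an aromatic carbon. The step that the two limits leave unreadable from compound 2 to compound 3 cannot be read in either direction because of the limit of > 20000 nM in this assay, at which 3 of the 3 values shown sit. No reading of order or change among the three measured compounds is possible, since all three sit at the same limit.

Compound 4 `CNc1ncnc2c1c(I)cn2[C@@H]1O[C@H](CO)[C@@H](O)[C@H]1O` is not yet measured. It arises from compound 1 by iodo in place of ethynyl on an aromatic carbon, the same change as that from compound 2 to compound 3, at the same place. The measured step gives no size to carry over because of the limit of > 20000 nM in this assay, at which 3 of the 3 values shown sit. The step that the limit leaves unreadable from compound 1 to compound 4 is expected to be small, resting on the limit that compound 1 shows and on compound 3 sharing that limit after the same change. For compound 4 the expected value is 25000 nM, estimated within 10000 nM to 60000 nM, and most likely it is again reported only as a limit.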

Compound 4, half-maximal inhibitory concentration: > 100000 nM
Compound 4 was reported as a limit (the forecaster's own chance of this, stated with the estimate: 85%); middle value at least 4.0-fold (0.60 log units) from the limit.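

In this assay compound 4 gives > 100000 nM, which is a limit of the assay and not a number. Within the data shown here, no step from compound 1 to compound 4 can be read, because compound 1 also stands only as a limit: the limit of > 20000 nM in this assay, at which 3 of the 4 values shown sit. The compounds shown leave open whether iodo in place of ethynyl changes the read-out at all, and at what concentration any of the four reaches half-maximal inhibition.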